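This account rests on a few compounds, and the source may have more. Where it says the series, first, only, none or still open, it means among the compounds named here.

Going by the values given here, in a functional assay on HCT-116 cells (Homo sapiens) for antiproliferative activity, read by sulforhodamine B assay, with a stated time of 72 h (a lower number here means a stronger inhibitor, a higher number a weaker inhibitor), compound 1 (`OC[C@H]1O[C@@H](n2cnc3c(NCCC4=CCCCC4)ncnc32)[C@H](O)[C@@H]1O`) gives 6000 nM, the lower of the two numbers measured so far. Compound 2 (`OC[C@H]1O[C@@H](n2cnc3c(NCCNc4ccccc4)ncnc32)[C@H](O)[C@@H]1O`) gives 30000 nM, and this side-chain change amounts to a 5.0-fold higher number from compound 1 to compound 2 (0.70 log units; beyond the scatter), a modest step beyond the scatter. Compound 3 (`OC[C@H]1O[C@@H](n2cnc3c(NCCC4=CCCCC4)nc(Cl)nc32)[C@H](O)[C@@H]1O`) keeps the side chain of compound 1 and differs on the shared core: chloro in place of hydrogen on an aromatic carbon. This is chloro in place of hydrogen on an aromatic carbon, between two ring nitrogen atoms. Among the compounds with values here, the one measured step lies in the side chain, so no measured step speaks directly to this change. No step beyond the scatter is therefore expected in this assay, in either direction. The expected change is a 1.2-fold lower number from compound 1 to compound 3 (0.08 log units; within the scatter). The estimated value for compound 3 is 5000 nM, with an expected range from 1800 nM to 15000 nM.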

Compound 3, half-maximal inhibitory concentration: 90000 nM
Beside the measured number, compound 3's estimate is 18-fold (1.26 log units) below it; the whole stated range lies below it.
By their numbers in this assay, from the lowest: compound 1; then compound 2; then compound 3.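

With the side chain of compound 1 held fixed in this assay, chloro in place of hydrogen on the aromatic carbon between two ring nitrogen atoms gives a 15-fold higher number from compound 1 to compound 3 (1.18 log units; beyond the scatter) and counts as a large step. Going by these compounds alone, the only earlier step, a 5.0-fold higher number from compound 1 to compound 2 (0.70 log units; beyond the scatter), lay in the side chain and was modest, so it said nothing about the shared core. This pair shows that the core position is sensitive to this change, with one added heavy atom moving the number further than the side-chain change did. Nothing available explains this loss of activity.

The compounds shown leave open whether the step is specific to chloro or would also appear with fluoro, methyl or an amine on the same carbon. They also leave open whether chloro has a similar effect alongside the anilino side chain of compound 2.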